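Cytotoxicity of a 2-Chlorophenyl Variant in a Pyridine Series

A few compounds are considered here, and "the series" means these few. Any claim that something is new, unique, unknown or untested is made for them only; others in the source may bear on it.

Compound 3 `COc1nc(-c2ccc(Cl)c(F)c2)ccc1[C@@H](c1ccccc1)[C@@](O)(CCN(C)C)c1cccc2ccccc12` is the only one of the three measured compounds for which a toxicity assay on Vero cells (Chlorocebus sabaeus) for cytotoxicity (on this read-out lower numbers stand for higher toxicity in this test and higher numbers for lower toxicity in this test), gives a limit rather than a number: compound 3 reads > 50 ug/mL, which is the limit of > 50 ug/mL in this assay, at which 1 of the 3 values shown sits. Compound 1 `COc1nc(C2CCCCC2)ccc1[C@@H](c1ccccc1)[C@@](O)(CCN(C)C)c1cccc2ccccc12` gives 32.3 ug/mL in this assay. Compound 2 `COc1nc(-c2ccsc2)ccc1[C@@H](c1ccccc1)[C@@](O)(CCN(C)C)c1cccc2ccccc12` gives 24.4 ug/mL. The measured steps were an at least 1.5-fold higher number from compound 1 to compound 3 (0.18 log units; that floor lies within the scatter) and an at least 2.0-fold higher number from compound 2 to compound 3 (0.31 log units; beyond the scatter), while a 1.3-fold lower number from compound 1 to compound 2 (0.12 log units; within the scatter). Compound 4 `COc1nc(-c2ccccc2Cl)ccc1[C@@H](c1ccccc1)[C@@](O)(CCN(C)C)c1cccc2ccccc12` differs from compound 3 by 2-chlorophenyl in place of 4-chloro-3-fluorophenyl on an aromatic carbon. Among the compounds with values here, both steps that bear on this change exchange a non-aryl ring for an aryl ring; here one aryl ring replaces another, and no measured step covers such an exchange. The step is therefore expected to be an at least 1.1-fold lower number from compound 3 to compound 4 (0.04 log units; that floor lies within the scatter), small. Compound 4 is estimated at 45 ug/mL, with a range from 25 ug/mL to 100 ug/mL.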

Compound 4, half-maximal cytotoxic concentration: > 50 ug/mL
Compound 4: only a limit was reported; the forecaster's own chance of this, stated with the estimate: 45%; middle value at least 1.1-fold (0.04 log units) away from the limit.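

In this assay compound 4 gives > 50 ug/mL, a limit and not a number, so a second substituted phenyl group at this position also reaches the limit: the limit of > 50 ug/mL in this assay, at which 2 of the 4 values shown sit. With 2-chlorophenyl in place of thiophen-3-yl the result is an at least 2.0-fold higher number from compound 2 to compound 4 (0.31 log units; beyond the scatter), and with 2-chlorophenyl in place of cyclohexyl it is an at least 1.5-fold higher number from compound 1 to compound 4 (0.18 log units; that floor lies within the scatter). The step between compound 3 and compound 4 cannot be read, as both values are limits.

On these data alone, how the two halogenated phenyl groups rank against each other remains open. So does whether a phenyl group carrying an amine or a carboxylic acid would also reach the limit.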